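Cyclobutylmethyl for oxan-4-yl on the amide-type nitrogen

This account rests on a few compounds, and the source may have more. Where it says the series, first, only, none or still open, it means among the compounds named here.

In a physicochemical assay for lipophilicity (on this read-out lower numbers stand for lower lipophilicity and higher numbers for higher lipophilicity), compound 1 (`O=C(CN(C(=O)c1ccc(-c2ccccn2)cc1)C1CCCOC1)Nc1cc(F)cc(F)c1`) gives 2.7 and compound 2 (`O=C(CN(C(=O)c1ccc(-c2ccccn2)cc1)C1CCOCC1)Nc1cc(F)cc(F)c1`) gives 2.5 within the scatter of each other. Compound 3 (`O=C(CN(CC1CCC1)C(=O)c1ccc(-c2ccccn2)cc1)Nc1cc(F)cc(F)c1`) has cyclobutylmethyl in place of oxan-4-yl on an amide-type nitrogen. Within the data shown here, the one measured step (a number 0.20 log units lower from compound 1 to compound 2 (within the scatter)) exchanges oxan-3-yl for oxan-4-yl, two groups that both contain oxygen, so no measured step sizes this change. The expected step (a number 1.00 log units higher from compound 2 to compound 3 (beyond the scatter)) is upward and beyond the scatter, an estimate resting on the structural change alone. For compound 3 the expected value is 3.5 (estimated range 3 to 4).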

Compound 3, distribution coefficient: 3.5
Beside the measured number, compound 3's estimate shows no gap at the digits printed; measured number inside the range.
By their numbers in this assay, from the lowest: compounds 2 and 1 (each within the scatter of the next); then compound 3.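

Among these compounds, with cyclobutylmethyl on the amide-type nitrogen, this assay shows the first steps at this position beyond the scatter (a number 1.00 log units higher from compound 2 to compound 3 (beyond the scatter)) and (a number 0.80 log units higher from compound 1 to compound 3 (beyond the scatter)). Both steps replace an oxygen-containing oxane ring with an all-carbon group that has no hydrogen-bond acceptor, and both go upward. Nothing available explains these steps.

The compounds shown do not separate losing the ring oxygen from changing the ring, a distinction cyclohexyl on this nitrogen could test. Going by these compounds, how an amine or a carboxylic acid here would read in this assay stays open.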